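The source may hold more compounds than are shown below. What is called first, only, known or untested is meant among the compounds shown, and "the series" means these compounds.

In a functional assay on the whole organism for inhibition, with Spinacia oleracea as the target, read by spectrophotometry, with a stated time of 4 h (on this read-out lower numbers stand for stronger inhibition and higher numbers for weaker inhibition), three compounds have been measured:

Compound 1 `CC(C)(C)c1cnc(C(=O)Nc2cccc(O)c2)cn1` gives 478000 nM.
Compound 2 `CC(C)c1cnc(C(=O)/C=C/c2ccccc2O)cn1` gives 167000 nM.
Compound 3 `CCCCCCCCSc1cc(C(N)=S)ccn1` gives 72000 nM.

On these numbers compound 2 stands second highest of the three. Its nearest neighbour is compound 3, which gives a lower number, and the gap between the two lies beyond the usual scatter. Its furthest neighbour is compound 1, which gives a higher number, again beyond the scatter. No two of these compounds differ in one place only, so no single step between measured compounds is available.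

The unmeasured compound 4 `CCCc1cnc(C(=O)/C=C/c2ccccc2O)cn1` differs from compound 2 in a single place: propyl in place of isopropyl on an aromatic carbon. The two compounds contain the same atoms, joined differently. There is no measured step of this kind in the set to lean on. A change of this size, with no ring, no donor and no acceptor added or removed, is expected to leave the number close to that of compound 2, with no step beyond the scatter in either direction. Compound 4 is therefore estimated at 170000 nM, within a range of 60000 nM to 480000 nM, which corresponds to an expected step of a 1.0-fold higher number from compound 2 to compound 4 (0.01 log units; within the scatter).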

Compound 4, half-maximal inhibitory concentration: 187000 nM
Estimate against measurement, compound 4: 1.1-fold (0.04 log units) below, and the stated range covers the measured number.
By their numbers in this assay, from the lowest: compound 3; then compounds 2 and 4 (each within the scatter of the next); then compound 1.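

Within the data shown here, the pair gives the first step in this assay between compounds that differ in one place only, and that step, a 1.1-fold higher number from compound 2 to compound 4 (0.05 log units; within the scatter), lies within the scatter. Propyl and isopropyl, on an aromatic carbon next to the ring nitrogen, therefore cannot be told apart in this read-out, at least on this core with its unchanged remainder. The earlier compounds shown here could not show this, as each of them differed from the others in more than one place, and the finding rests on this single pair.

As far as these compounds go, whether a longer chain such as hexyl, an amine or a carboxylic acid at this same place would also leave the number within the scatter remains open. What lies behind the result also stays open, as no measurement of another kind bears on it.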